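Indoline and tetrahydroquinoline quinazolines with acrylamide tails

This account rests on a few compounds, and the source may have more. Where it says the series, first, only, none or still open, it means among the compounds named here.

Measured compounds in a functional assay on PC-3 cells (Homo sapiens) for antiproliferative activity, read by MTT assay, with a stated time of 72 h; a higher number here means a weaker inhibitor, a lower number a stronger inhibitor:
compound 1 `O=C(/C=C/CN1CCCC1)Nc1cc2c(N3CCc4ccccc43)ncnc2cc1O[C@@H]1CCOC1` gives 1510 nM
compound 2 `O=C(/C=C/CN1CCCCC1)Nc1cc2c(N3CCc4ccccc43)ncnc2cc1O[C@@H]1CCOC1` gives 4510 nM
compound 3 `COc1cc2ncnc(N3CCCc4ccccc43)c2cc1NC(=O)/C=C/CN1CCCC1` gives 1740 nM

Compound 1 and compound 2 share a core and differ only by the change (piperidin-1-yl in place of pyrrolidin-1-yl on a saturated chain carbon bound to a double-bonded chain carbon); in this assay this change gives a 3.0-fold higher number from compound 1 to compound 2 (0.48 log units; beyond the scatter). Compound 3 carries a different core, and the difference between the two cores is not broken down here. Compound 4 `COc1cc2ncnc(N3CCCc4ccccc43)c2cc1NC(=O)/C=C/CN1CCCCC1`, not yet measured, stands to compound 3 as compound 2 stands to compound 1: the change is piperidin-1-yl in place of pyrrolidin-1-yl on a saturated chain carbon bound to a double-bonded chain carbon, the same kind of change at the same place. Among the measured compounds shown here, for compound 4 a step of about the same size is expected, a 2.8-fold higher number from compound 3 to compound 4 (0.44 log units; beyond the scatter), because the only precedent is a 3.0-fold higher number from compound 1 to compound 2 (0.48 log units; beyond the scatter) and the tail is the same in both pairs. For the measured compounds named here, compound 4 is therefore estimated at 4800 nM in this assay, with a range from 2200 nM to 10000 nM to allow for the single precedent and the changed core.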

Compound 4, half-maximal inhibitory concentration: 5780 nM
Compound 4: the middle estimate sits 1.2-fold (0.08 log units) below what was measured, and the stated range covers the measured number.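

In this assay the change from pyrrolidin-1-yl to piperidin-1-yl on the saturated chain carbon gives a 3.3-fold higher number from compound 3 to compound 4 (0.52 log units; beyond the scatter). The step carries over from one core to the other with no detectable change in size: the same change on two cores in this assay, a 3.0-fold higher number (0.48 log units; beyond the scatter) from compound 1 to compound 2 and a 3.3-fold higher number (0.52 log units; beyond the scatter) from compound 3 to compound 4, 1.1-fold (0.05 log units) apart, within the scatter of two such steps. Among the compounds shown here, with only two pairs in one assay, this shows agreement on these two cores alone; it does not show that the step holds on other cores, and it does not explain the weaker reading with piperidin-1-yl.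

Still open, from the compounds shown here alone, is how other amines at this place, such as morpholin-4-yl or dimethylamino, would read on either core. The effect of each core alone also remains unresolved, as compound 1 and compound 3 differ in more than one place.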